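Adding an Acetyl Group to a Potent Hydroxy Compound

The source may hold more compounds than are shown below. What is called first, only, known or untested is meant among the compounds shown, and "the series" means these compounds.

In an ADME assay on HEp-2 cells (Homo sapiens) for cytotoxicity, read by MTT assay, with a stated time of 72 h (a higher number here means a weaker inhibitor, a lower number a stronger inhibitor), compound 2 (`COc1ccc(C2=C(c3cc(OC)c(OC)c(OC)c3)C(=O)C(O)C2)cc1Cl`) gives < 1 ug/mL as its reading, which is a limit of the assay and not a number. As far as these compounds go, this places compound 2 at the strong end of the readings so far, though its true value remains unknown. Compound 1 (`COc1ccc(C2=C(c3cc(OC)c(OC)c(OC)c3)C(=O)C(OC(C)=O)C2)cc1OC(C)C`) also carries an acetoxy group, and its reading of > 100 ug/mL is likewise a limit.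

Compound 3 (`COc1ccc(C2=C(c3cc(OC)c(OC)c(OC)c3)C(=O)C(OC(C)=O)C2)cc1Cl`) is compound 2 with one change, hydroxy to acetoxy: acetyl in place of hydrogen on an oxygen on a saturated carbon. Going by the values given here, no pair of measured compounds shows this change alone, so its size is uncertain. Among the compounds with values here, a moderate rise in the number is expected, meaning a weaker inhibitor, and the only measured acetoxy example is compound 1 at > 100 ug/mL as a reading. The expected change is an at least 3.0-fold higher number from compound 2 to compound 3 (0.47 log units; beyond the scatter) in that direction, likely beyond the usual scatter. Compound 3 is expected at 3 ug/mL with a range from 0.4 ug/mL to 40 ug/mL (an estimate, not a measurement).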

Compound 3, half-maximal inhibitory concentration: < 1 ug/mL
Compound 3 ended at the assay's limit; the forecaster's own chance of this, stated with the estimate: 40%; middle value at least 3.0-fold (0.47 log units) away from the limit.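

The acetoxy group on this saturated carbon does not by itself move a compound away from the strong end of this assay: compound 3 carries it and still sits at the same limit as compound 2. With the acetoxy group held fixed, chloro in place of isopropoxy on an aromatic carbon gives an at least 100-fold lower number from compound 1 to compound 3 (2.00 log units; beyond the scatter), so in this pair the weak reading of compound 1 goes with the isopropoxy group and not with the acetoxy group. The step from hydroxy to acetoxy itself cannot be read, and any difference between compound 2 and compound 3 stays hidden at their shared limit: the limit of < 1 ug/mL in this assay, at which 2 of the 3 values shown sit.

As far as these compounds go, how far past that limit compound 2 and compound 3 each lie remains unknown, so the acetoxy group may weaken the compound somewhat or not at all. Also open, from the compounds shown here alone, is whether an amine or a longer ester chain at this place would stay at the strong end, and whether a hydroxy group in place of the acetoxy group would change the reading of compound 1.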